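The source may hold more compounds than are shown below. What is called first, only, known or untested is meant among the compounds shown, and "the series" means these compounds.

Compound 1, `O=[N+]([O-])c1cc(-c2nnc(SCc3ccccc3)n2Cc2ccccc2)cc([N+](=O)[O-])c1`: in an ADME assay on HepG2 cells (Homo sapiens) for cytotoxicity, with a stated time of 48 h (a lower number here means a stronger inhibitor, a higher number a weaker inhibitor), compound 1 gives > 30000 nM, which is a limit of the assay rather than a number.
Compound 2, `O=[N+]([O-])c1cc(-c2nnc(SCc3ccc(Cl)cc3)n2Cc2ccccc2)cc(C(F)(F)F)c1`: in this assay compound 2 gives > 30000 nM, again a limit.
Compound 3, `O=[N+]([O-])c1cc(-c2nnc(SCc3ccc(Cl)c(Cl)c3)n2Cc2ccccc2)cc(C(F)(F)F)c1`: in this assay compound 3 gives > 30000 nM, also a limit.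

Compound 3 therefore stands at the limit of > 30000 nM in this assay, at which 3 of the 3 values shown sit, and no order among the three compounds can be read. The change to compound 4, `O=[N+]([O-])c1cc(-c2nnc(SCc3ccccc3)n2Cc2ccccc2)cc(C(F)(F)F)c1`, is phenyl in place of 3,4-dichlorophenyl on a saturated chain carbon bound to a sulfur. Going by the values given here, the only measured step of the same kind, a step that the two limits leave unreadable from compound 2 to compound 3, runs the other way and its size is unreadable, since both ends are limits. Among the compounds with values here, no measured compound leaves the limit, so the step that the limit leaves unreadable from compound 3 to compound 4 is expected to be none beyond the scatter. Compound 4 is thus estimated at 40000 nM, within 20000 nM to 100000 nM, most probably reported again only as a limit.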

Compound 4, half-maximal inhibitory concentration: 21500 nM
Compound 4: middle estimate off by 1.9-fold (0.27 log units), on the high side; the range from low to high includes it.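

In this assay compound 4 is the only compound that gives a number rather than a limit: the limit of > 30000 nM in this assay, at which 3 of the 4 values shown sit.
Phenyl in place of 3,4-dichlorophenyl gives an at least 1.3-fold lower number from compound 3 to compound 4 (0.14 log units; that floor lies within the scatter), hydrogen in place of chloro gives an at least 1.3-fold lower number from compound 2 to compound 4 (0.14 log units; that floor lies within the scatter), and trifluoromethyl in place of nitro gives an at least 1.3-fold lower number from compound 1 to compound 4 (0.14 log units; that floor lies within the scatter).
Each step is only a floor set by a limit, so none of these three changes can yet be said to move the number beyond the scatter.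

From the compounds shown here alone, what stays open is how this assay would read with an amine or a carboxylic acid in place of the phenyl on the saturated chain carbon bound to a sulfur.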